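The compounds below may be only part of what the source reports. "The series", "measured", "known", "first", "only" and "open" are said of these compounds alone.

In an ADME assay on MRC5 cells (Homo sapiens) for cytotoxicity, read by fluorescence, with a stated time of 72 h (on this read-out higher numbers stand for weaker inhibition and lower numbers for stronger inhibition), compound 1 `CC1(COc2ccc(OC(F)(F)F)cc2)Cn2cc([N+](=O)[O-])nc2O1` gives > 64000 nM, which is a limit of the assay and not a number. Compound 2 `CC1(COc2ccccc2)Cn2cc([N+](=O)[O-])nc2O1` gives > 64000 nM, which is also a limit and not a number. Compound 2 therefore has no exact position on the scale, and the evidence so far is the limit of > 64000 nM in this assay, at which 2 of the 2 values shown sit.

Compound 3 `CC1(COc2ccc(F)cc2)Cn2cc([N+](=O)[O-])nc2O1` departs from compound 2 in a single place: fluoro in place of hydrogen on an aromatic carbon. This puts fluoro in place of hydrogen on an aromatic carbon, para to a large group, turning phenyl into 4-fluorophenyl.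

For the measured compounds named here, the only measured step that bears on this change is a step that the two limits leave unreadable from compound 1 to compound 2, which also alters a group on an aromatic carbon. It has no readable size, so it offers no sign of a shift and no direction for one. No step beyond the usual scatter is therefore expected in this assay. The expected step is a number no higher from compound 2 to compound 3 (the limit leaves the size open). For compound 3 the estimate is 64000 nM, with an expected range from 30000 nM to 64000 nM, and the assay will most likely report only a limit again.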

Compound 3, half-maximal inhibitory concentration: > 64000 nM
Compound 3 was reported as a limit; the forecaster's own chance of this, stated with the estimate: 85%; the middle value lies on the limit itself.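

In this assay, for the compounds shown here, compound 3, like compound 1 and compound 2, is reported only as a limit and not as a number, so no step among the three can be read. The compounds shown leave open where their actual values lie and whether hydrogen, fluoro or trifluoromethoxy on the aromatic carbon makes any difference to this read-out.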